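A Fluoro Swap at the Assay Limit

A few compounds are considered here, and "the series" means these few. Any claim that something is new, unique, unknown or untested is made for them only; others in the source may bear on it.

In an ADME assay on Raji cells (Homo sapiens) for cytotoxicity, read by luminescence, with a stated time of 72 h (on this read-out higher numbers stand for an effect only at larger amounts of compound and lower numbers for an effect already at smaller amounts), compound 3 (`CCCCOc1cccc(-c2[nH]c3cc(OC)ccc3c(=O)c2C(=O)OCC)c1`) gives > 21500 nM as a limit, not a number. Compound 1 (`CCOC(=O)c1c(-c2cc(F)cc(OC)c2)[nH]c2cc(OC)ccc2c1=O`) gives > 21500 nM as a limit too. Compound 2 (`CCOC(=O)c1c(-c2cccc(-c3ccccc3)c2)[nH]c2cc(OC)ccc2c1=O`) likewise gives > 21500 nM as a limit. The data offer only the limit of > 21500 nM in this assay, at which 3 of the 3 values shown sit, and no readable number. Compound 4 (`CCOC(=O)c1c(-c2cccc(F)c2)[nH]c2cc(OC)ccc2c1=O`) follows from compound 3 through fluoro in place of butoxy on an aromatic carbon with fluoro in place of butoxy on an aromatic carbon. Within the data shown here, the only measured step, a step that the two limits leave unreadable from compound 2 to compound 3, gives no size to carry over, so no step in either direction is expected in this assay beyond the scatter. The expected move is a step that the limit leaves unreadable from compound 3 to compound 4 on this estimate. For compound 4 the estimate is 25000 nM with a range from 12000 nM to 50000 nM and another limit is expected.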

Compound 4, half-maximal effective concentration: > 21500 nM
Compound 4 ended at the assay's limit; the forecaster's own chance of this, stated with the estimate: 85%; the middle value does not contradict the limit.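

Among these compounds, no step between compound 1, compound 2, compound 3 and compound 4 can be read in this assay, since all four stop at the same limit: the limit of > 21500 nM in this assay, at which 4 of the 4 values shown sit. In this assay the compounds shown leave open which change to the shared core, if any, would give a readable number.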